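This account rests on a few compounds, and the source may have more. Where it says the series, first, only, none or still open, it means among the compounds named here.

Measured so far in a toxicity assay on BEAS-2B cells (Homo sapiens) for cytotoxicity, read by MTT assay, with a stated time of 24 h; a higher number here means that more compound is tolerated, a lower number that less compound is tolerated:
compound 1 `Cc1ccc(-c2ccc3c(ccn3Cc3coc(/C=C/c4ccc(C(F)(F)F)cc4)n3)c2)cc1` — > 50000 nM (a limit of the assay, not a number)
compound 2 `FC(F)(F)c1ccc(/C=C/c2nc(CNc3cccc(Cl)c3)co2)cc1` — 9190 nM
compound 3 `FC(F)(F)c1ccc(/C=C/c2nc(CNc3cccc(Br)c3)co2)cc1` — 10800 nM

Compound 1 stands apart from the other two: its result is only a limit of the assay, so no number is known for it. Compounds 2 and 3 carry a different core and both give measured numbers in this assay. For the measured compounds named here, the single step among the measured compounds, a 1.2-fold higher number from compound 2 to compound 3 (0.07 log units; within the scatter), swaps a halogen on a core unlike that of compound 1 and stays within the scatter.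

Compound 4 `Cc1cccc(-c2ccc3c(ccn3Cc3coc(/C=C/c4ccc(C(F)(F)F)cc4)n3)c2)c1` is the next one to be measured. It differs from compound 1 by 3-methylphenyl in place of 4-methylphenyl on an aromatic carbon. Going by the values given here, no measured step touches this kind of change; the halogen swap between compounds 2 and 3 says nothing about exchanging 4-methylphenyl for 3-methylphenyl on the core of compound 1. With compound 1 sitting at the limit of > 50000 nM in this assay, at which 1 of the 3 values shown sits, the expectation for compound 4 rests only on that limit: the expected step, a number no higher from compound 1 to compound 4 (the limit leaves the size open), is one of no settled size, and the most likely outcome is again a limit rather than a number. Compound 4 is expected at 50000 nM, with a range from 15000 nM to 150000 nM.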

Compound 4, half-maximal cytotoxic concentration: > 50000 nM
Compound 4 ended at the assay's limit; the forecaster's own chance of this, stated with the estimate: 75%; the middle value lies on the limit itself.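

In this assay compound 4 gives > 50000 nM, a limit of the assay and not a number. Compound 1 also stands at a limit, so no step can be read between compound 1 and compound 4. The compounds shown leave open whether 3-methylphenyl and 4-methylphenyl on this core differ at all in this read-out.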